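A few compounds are considered here, and "the series" means these few. Any claim that something is new, unique, unknown or untested is made for them only; others in the source may bear on it.

Measured compounds:
- compound 1 `Nc1nn2c(O)cc(-c3ccccc3F)nc2c1[N+](=O)[O-]`: in a functional assay on L929 cells (Mus musculus) for inhibition (a higher number here means a weaker inhibitor of growth, a lower number a stronger inhibitor of growth), compound 1 gives > 50 ug/mL, which is a limit of the assay, not a number.
- compound 2 `Nc1nn2c(O)cc(CNNCCO)nc2c1[N+](=O)[O-]`: in this assay compound 2 gives > 50 ug/mL, again a limit of the assay rather than a number.

Among the compounds with values here, compound 2 therefore stands only at the limit in this assay; the single step so far, a step that the two limits leave unreadable from compound 1 to compound 2, cannot be read, because both ends sit at the limit of > 50 ug/mL in this assay, at which 2 of the 2 values shown sit.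

Compound 3 `Nc1nn2c(O)cc(CNNC(N)S)nc2c1[N+](=O)[O-]` is the next member of the series. Relative to compound 2 the change is amino(sulfanyl)methyl in place of 2-hydroxyethyl on an amine nitrogen. Within the data shown here, no measured step bears directly on this change, and the one step on record gives no size in either direction. Compound 3 is accordingly expected to remain at the limit in this assay, with the step that the limit leaves unreadable from compound 2 to compound 3 estimated as none beyond the scatter. The estimate for compound 3 is 70 ug/mL, expected to lie between 30 ug/mL and 200 ug/mL, most probably reported only as a limit.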

Compound 3, concentration for 50% growth inhibition: > 50 ug/mL
Compound 3 was reported as a limit; the forecaster's own chance of this, stated with the estimate: 80%; the middle value lies beyond the limit too.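

In this assay compound 3 gives > 50 ug/mL, a limit of the assay and not a number. No step among compound 1, compound 2 and compound 3 can be read: the limit of > 50 ug/mL in this assay, at which 3 of the 3 values shown sit.

The compounds shown leave open how the 2-fluorophenyl, 2-hydroxyethyl and amino(sulfanyl)methyl groups compare in growth inhibition.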